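The source may hold more compounds than are shown below. What is called first, only, known or untested is meant among the compounds shown, and "the series" means these compounds.

Working notes on the series built on the core of compound 1 `Cc1cc(C)cc(-c2c(O)nc3cc(Cl)c(NC(=O)c4cnccn4)cc3c2OCCC2CCCCN2)c1`. In a functional assay on cells (Pituitary gland cell) for antagonist activity at Gonadotropin-releasing hormone receptor (Rattus norvegicus) (a lower number here means a stronger inhibitor, a higher number a weaker inhibitor), compound 1 gives 1.8 nM. Compound 2 `CC(=O)OCc1cc(C)cc(-c2c(O)nc3cc(Cl)c([N+](=O)[O-])cc3c2OCCC2CCCCN2)c1` gives 45 nM in this assay. Compound 3 `O=[N+]([O-])c1cc2c(OCCC3CCCCN3)c(-c3cccs3)c(O)nc2cc1Cl` gives 220 nM in this assay, the highest of the three numbers; its nearest neighbour is compound 2 and the furthest is compound 1. Among the compounds with values here, the only measured step that touches this position is a 4.9-fold higher number from compound 2 to compound 3 (0.69 log units; beyond the scatter). Compound 4 `O=[N+]([O-])c1cc2c(OCCC3CCCCN3)c(-c3cc(Cl)cc(Cl)c3)c(O)nc2cc1Cl` differs from compound 3 by 3,5-dichlorophenyl in place of thiophen-2-yl on an aromatic carbon. The change once more exchanges the five-membered ring for a six-membered ring of carbon only, so that measured step, read in reverse, is the closest guide; compound 1 likewise carries a six-membered aromatic ring of carbon only at this place, though it differs elsewhere too, so its number is only a loose pointer. The expectation for compound 4 is therefore a lower number, a 7.3-fold lower number from compound 3 to compound 4 (0.87 log units; beyond the scatter). Compound 4 is estimated at 30 nM in this assay, with a range from 8 nM to 120 nM.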

Compound 4, half-maximal inhibitory concentration: 24 nM
Beside the measured number, compound 4's estimate is 1.3-fold (0.10 log units) above it, and the stated range covers the measured number.
By their numbers in this assay, from the lowest: compound 1; then compounds 4 and 2 (each within the scatter of the next); then compound 3.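

Replacing thiophen-2-yl with 3,5-dichlorophenyl gives a 9.2-fold lower number from compound 3 to compound 4 (0.96 log units; beyond the scatter) in this assay and shows that this position, ortho to a hydroxy group, responds to this exchange beyond the scatter. Exchanging 3-(acetoxymethyl)-5-methylphenyl for 3,5-dichlorophenyl gives a 1.9-fold lower number from compound 2 to compound 4 (0.27 log units; within the scatter) and does not separate these two substituted phenyl groups, although both differ from thiophen-2-yl by more than the scatter. Nothing measured here explains the gap between the five-membered ring and the two six-membered rings.

Open, from the compounds shown here alone, is whether a phenyl ring carrying an amine or a carboxylic acid, or a longer chain, would fit this pattern at this place. Also open, going by these compounds, is whether the same exchange would have a similar effect alongside the amide of compound 1, which differs from compound 4 in more than one place.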